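The source may hold more compounds than are shown below. What is called first, only, known or untested is meant among the compounds shown, and "the series" means these compounds.

Compound 1 `COc1ccc(C(=O)Nc2ncc(C(Oc3ccc4cc(Br)ccc4c3)c3ccc(Cl)cc3)s2)cc1` was tested in an ADME assay on HepG2 2.2.15 cells (Homo sapiens) for cytotoxicity; a lower number here means that less compound is tolerated, a higher number that more compound is tolerated. In this assay compound 1 gives > 50000 nM, which is a limit of the assay rather than a number. Compound 2 `COc1ccc(C(=O)Nc2ncc(C(Nc3cccc4ccccc34)c3ccc(Cl)cc3)s2)cc1` stands at the same mark: in this assay compound 2 gives > 50000 nM, again a limit. Going by the values given here, the one measured step between them, a step that the two limits leave unreadable from compound 1 to compound 2, cannot be sized, since both ends sit at the limit of > 50000 nM in this assay, at which 2 of the 2 values shown sit.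

Compound 3 `COc1ccc(C(=O)Nc2ncc(C(Sc3ccc4ccccc4c3)c3ccc(Cl)cc3)s2)cc1` has not yet been measured. It differs from compound 2 by (naphthalen-2-yl)sulfanyl in place of (naphthalen-1-yl)amino on a saturated chain carbon bound to two aromatic carbons. Among the compounds with values here, no measured step speaks to this exchange of a sulfanyl link for an amino link; the only step recorded could not be read, so the expectation rests on compound 2 alone. Compound 2 sits at the limit, and compound 3 is expected to do the same, so the expected step of a number no higher from compound 2 to compound 3 (the limit leaves the size open) is none beyond the scatter. For compound 3 the estimate in this assay is 50000 nM, with a range from 25000 nM to 100000 nM.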

Compound 3, half-maximal cytotoxic concentration: "not toxic" (no number reported)
For compound 3 the study gives words and no number, so the estimate cannot be set against anything.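

Going by these compounds alone, for compound 3, this assay gives only the words "not toxic", so no step from compound 2 to compound 3 can be read. The compounds shown leave open whether exchanging the group on the saturated chain carbon changes tolerance at all, since the readings stop at a limit: the limit of > 50000 nM in this assay, at which 2 of the 3 values shown sit.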